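The source may hold more compounds than are shown below. What is called first, only, known or untested is meant among the compounds shown, and "the series" means these compounds.

Measured in a functional assay on A549 cells (Homo sapiens) for inhibition (a higher number here means a weaker inhibitor, a lower number a stronger inhibitor), so far:
- compound 1 `CC(C)c1cc(-c2n[nH]c(=O)n2-c2cccc(NC(=O)CCCCCC(=O)NO)c2)c(O)cc1O` at 1600 nM
- compound 2 `CC(C)c1cc(-c2n[nH]c(=O)n2-c2cccc(C(=O)NCCCC(=O)NO)c2)c(O)cc1O` at 4600 nM
- compound 3 `CC(C)c1cc(-c2n[nH]c(=O)n2-c2cccc(NC(=O)CCCCCCC(=O)NO)c2)c(O)cc1O` at 1600 nM

Compound 1 is level with compound 3 at 1600 nM and together they hold the lowest of the three numbers. Compound 4 `CC(C)c1cc(-c2n[nH]c(=O)n2-c2cccc(NC(=O)CCCCC(=O)NO)c2)c(O)cc1O` comes from compound 3 by hydroxycarbamoyl in place of 2-(hydroxycarbamoyl)ethyl on a saturated chain carbon, four bonds along the chain from a carbonyl carbon with hydroxycarbamoyl in place of 2-(hydroxycarbamoyl)ethyl on a saturated chain carbon, four bonds along the chain from a carbonyl carbon. For the measured compounds named here, the one measured step of this kind is no change at the digits printed from compound 1 to compound 3 (within the scatter) and it stayed within the scatter. Going by the values given here, compound 2 differs in more than one place and gives no clean step. No step beyond the scatter is expected in this assay and the estimated size is a 1.3-fold higher number from compound 3 to compound 4 (0.10 log units; within the scatter) with only a slight rise. For compound 4 the estimated value is 2000 nM and the expected range runs from 900 nM to 4500 nM as a working figure.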

Compound 4, half-maximal inhibitory concentration: 1600 nM
Beside the measured number, compound 4's estimate is 1.3-fold (0.10 log units) above it; the range from low to high includes it.
By their numbers in this assay, from the lowest: compounds 1, 3 and 4 (each within the scatter of the next); then compound 2.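

Hydroxycarbamoyl in place of 2-(hydroxycarbamoyl)ethyl, on a saturated chain carbon four bonds along the chain from a carbonyl carbon, gives in this assay no change at the digits printed from compound 3 to compound 4 (within the scatter), and the matching replacement of (hydroxycarbamoyl)methyl gives no change at the digits printed from compound 1 to compound 4 (within the scatter), so this chain tolerates all three lengths shown within the scatter. The exchange of (3-(hydroxycarbamoyl)propyl)carbamoyl for ((4-(hydroxycarbamoyl)butyl)carbonyl)amino on an aromatic carbon gives a 2.9-fold lower number from compound 2 to compound 4 (0.46 log units; beyond the scatter), a single change that does not separate amide direction from chain length. Nothing available explains this flat response.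

From the compounds shown here alone, whether a still shorter or longer chain, or a carboxylic acid in place of hydroxycarbamoyl, would hold this level remains open.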